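Swapping Cyano for Methoxy on the Aryl Group

The source may hold more compounds than are shown below. What is called first, only, known or untested is meant among the compounds shown, and "the series" means these compounds.

In a functional assay on EBC-1 cells (Homo sapiens) for antiproliferative activity, with a stated time of 72 h (on this read-out higher numbers stand for weaker inhibition and lower numbers for stronger inhibition), compound 1 (`Fc1cc(F)cc(-c2cc(F)c3ncc(Cc4ccc5ncccc5c4)n3c2)c1`) gives 790 nM and compound 2 (`N#Cc1ccc(-c2cc(F)c3ncc(Cc4ccc5ncccc5c4)n3c2)cc1F`) gives 145 nM as the lower of the two numbers. Compound 2 therefore stands as the stronger inhibitor of this pair. Within the data shown here, the one measured step shows a 5.4-fold lower number from compound 1 to compound 2 (0.74 log units; beyond the scatter) as 4-cyano-3-fluorophenyl takes the place of 3,5-difluorophenyl on the shared core.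

Compound 3 (`COc1ccc(-c2cc(F)c3ncc(Cc4ccc5ncccc5c4)n3c2)cc1F`) changes one group of compound 2 (methoxy in place of cyano on an aromatic carbon): methoxy in place of cyano on an aromatic carbon, ortho to a fluoro group and para to a large group. This turns 4-cyano-3-fluorophenyl into 3-fluoro-4-methoxyphenyl. Among the measured compounds shown here, no measured compound carries the methoxy, so the evidence is indirect. For the measured compounds named here, it rests on compound 2, the only measured compound with the cyano, and on a 5.4-fold lower number from compound 1 to compound 2 (0.74 log units; beyond the scatter) as the only step available. Compound 3 gives up that cyano, so a modest step toward a higher number, smaller than or similar to the measured one, is expected in this assay for this change. The estimate is a 2.2-fold higher number from compound 2 to compound 3 (0.34 log units; beyond the scatter) as the expected step. Compound 3 is expected at 320 nM (range 110 nM to 900 nM) on this estimate.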

Compound 3, half-maximal inhibitory concentration: 407 nM
Compound 3: the middle estimate sits 1.3-fold (0.10 log units) below what was measured; the range from low to high includes it.
By their numbers in this assay, from the lowest: compound 2; then compounds 3 and 1 (each within the scatter of the next).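

In this assay, the carbon ortho to a fluoro group and para to a large group proves sensitive to which group it carries: with the fluoro group kept, the exchange of cyano for methoxy gives a 2.8-fold higher number from compound 2 to compound 3 (0.45 log units; beyond the scatter) even though the two groups match in heavy atoms and hydrogen-bond acceptors as counted. The methoxy aryl group also gives a 1.9-fold lower number from compound 1 to compound 3 (0.29 log units; within the scatter), a step within the scatter, so among these three compounds the clear advantage over 3,5-difluorophenyl is seen only with 4-cyano-3-fluorophenyl and not with 3-fluoro-4-methoxyphenyl. No measurement offered here accounts for this difference between cyano and methoxy.

The compounds shown leave open how an amine, a carboxylic acid or a longer chain such as ethoxy would behave on this same carbon with the fluoro group kept. They also leave open whether the cyano would hold its standing without the fluoro group ortho to it, as neither of the two compounds that differ at this carbon lacks that fluoro group.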